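Nitro for chloro on the aryl piperazine of compound 2

The source may hold more compounds than are shown below. What is called first, only, known or untested is meant among the compounds shown, and "the series" means these compounds.

Measured compounds:
compound 1 `CCOC(=O)C1CCN(Cn2nc(C(C)c3ccc(CC(C)C)cc3)oc2=S)CC1` gives 41.8% in a functional assay on the whole organism (strain Swiss albino) for inhibition, with Mus musculus as the target, in the hot plate test, with stated times of 15 s and 60 min, at a dose of 10 mg/kg by the oral route; a lower number here means less inhibition, a higher number more inhibition at the dose given (going by the name of the read-out)
compound 2 `CC(C)Cc1ccc(C(C)c2nn(CN3CCN(c4ccc(Cl)cc4)CC3)c(=S)o2)cc1` gives 28% in this assay

Compound 2 stands lowest of the two numbers in this assay; its nearest neighbour is compound 1, which sits higher by a margin beyond the usual scatter. Within the data shown here, no step between the two measured compounds differing in one place is available, so the two values show only that compound 1 sits above compound 2.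

Compound 3 `CC(C)Cc1ccc(C(C)c2nn(CN3CCN(c4ccc([N+](=O)[O-])cc4)CC3)c(=S)o2)cc1` has not yet been measured in this assay. It differs from compound 2 in one place: nitro in place of chloro on an aromatic carbon. The change sits on an aromatic carbon of a six-membered aromatic ring of carbon only, para to a large group.

Among the measured compounds shown here, nothing among the measured compounds bears on a nitro for chloro exchange at this place, so no step beyond the scatter is expected from compound 2 to compound 3 in this assay; the expected step is a number 2 percentage points higher from compound 2 to compound 3 (within the scatter). For compound 3 the estimate in this assay is 30%, with a range from 15% to 45%.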

Compound 3, a percentage reported as inhibition, in the whole organism at one dose (the size of the read-out at that dose, not a potency): 36.2%
Compound 3: the middle estimate sits 6.2 percentage points below what was measured, within the range that was stated.
By their numbers in this assay, from the lowest: compounds 2, 3 and 1 (each within the scatter of the next, the first and the last beyond it).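

In this assay, among these compounds, nitro in place of chloro on this aromatic carbon gives a number 8.2 percentage points higher from compound 2 to compound 3 (within the scatter), the first reading of a single change. At this place, para to a large group, the read-out at this one dose thus does not separate 4-chlorophenyl from 4-nitrophenyl, even though nitro brings hydrogen-bond acceptors that chloro lacks. No measurement at hand accounts for this result or ties it to any property of either group.

From the compounds shown here alone, it remains open whether an amine, a methoxy group or a carboxylic acid on this aromatic carbon would give a step beyond the scatter from compound 2. Also open, going by these compounds, is whether 4-chlorophenyl and 4-nitrophenyl would still read alike at other doses.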